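Trimming a Cyclopentyl Amide Down to Propyl

The source may report more compounds than this note shows. Statements on the series, on what has been measured and on what is new or still open speak of the compounds shown alone.

Of the compounds shown here, two have been measured so far in a functional assay on HeLa cells (Homo sapiens) for antiproliferative activity, read by CCK-8 assay, with a stated time of 72 h; a lower number here means a stronger inhibitor of growth, a higher number a weaker inhibitor of growth. Compound 1 `CCC1C(=O)N(C)c2cnc(Nc3ccc(S(=O)(=O)NCC(C)C)cc3)nc2N1c1ccn(C)n1` gives 5310 nM. Compound 2 `CC[C@@H]1C(=O)N(C)c2cnc(-n3ccc4cc(C(=O)NC5CCCC5)ccc43)nc2N1C1CCCC1` gives 247 nM, the lower of the two numbers, and its gap to compound 1 lies beyond the usual scatter. Compound 3 `CCCNC(=O)c1ccc2c(ccn2-c2ncc3c(n2)N(C2CCCC2)[C@H](CC)C(=O)N3C)c1` differs from compound 2 in one place: propyl in place of cyclopentyl on an amide-type nitrogen. Among the measured compounds shown here, no measured pair shows this change, so nothing measured guides the expectation directly. The step is expected to be small, a 1.5-fold higher number from compound 2 to compound 3 (0.19 log units; within the scatter), likely a slight weakening that may not exceed the scatter. Compound 3 is estimated at 380 nM, with a range from 130 nM to 1100 nM.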

Compound 3, concentration for 50% growth inhibition: 238 nM
Compound 3: the middle estimate sits 1.6-fold (0.20 log units) above what was measured; low and high end bracket the measured number.
By their numbers in this assay, from the lowest: compounds 3 and 2 (each within the scatter of the next); then compound 1.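

In this assay, replacing cyclopentyl with propyl on the amide-type nitrogen gives a 1.0-fold lower number from compound 2 to compound 3 (0.02 log units; within the scatter), a step within the scatter. At this position, then, the five-membered carbon ring of compound 2 is not required to keep the growth inhibition seen there, and an open chain serves equally well. No supporting data are available to explain this match.

Still open, from the compounds shown here alone, is how far this freedom extends on the same nitrogen. A methyl group, a longer chain such as hexyl, or a chain ending in an amine or a carboxylic acid could each behave differently.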